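Aryl swap on compound 2: expectation for compound 4

The compounds below may be only part of what the source reports. "The series", "measured", "known", "first", "only" and "open" are said of these compounds alone.

Compound 1 `Cc1cnc(Nc2ccc(S(C)(=O)=O)cc2)nc1Nc1nc2ccccc2s1`: > 50000 nM in a functional assay on PC-3 cells (Homo sapiens) for antiproliferative activity, read by MTT assay, with a stated time of 48 h; a higher number here means a weaker inhibitor, a lower number a stronger inhibitor.
Compound 2 `Cc1cnc(Nc2ccc([N+](=O)[O-])cc2)nc1Nc1nc2ccccc2s1`: > 50000 nM.
Compound 3 `NS(=O)(=O)c1ccc(Nc2ncc(F)c(Nc3nc4ccc(Cl)cc4s3)n2)cc1`: 1430 nM.

Compound 2 stands at the limit of this assay, so its value is a limit and not a number. The same holds for compound 1, as the limit of > 50000 nM in this assay, at which 2 of the 3 values shown sit, shows. For the measured compounds named here, the only measured step on this part of the structure, a step that the two limits leave unreadable from compound 1 to compound 2, is therefore unreadable. Going by the values given here, compound 3 gives a number, but it differs from compound 2 in several places, so no step to it can be read.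

Compound 4 `Cc1cnc(Nc2cccc(F)c2)nc1Nc1nc2ccccc2s1` arises through (3-fluorophenyl in place of 4-nitrophenyl on a nitrogen on an aromatic ring). No readable step bears on this change, so compound 4 is expected to remain at the limit, with an estimated 50000 nM (10000 nM to 100000 nM). The expected step of a number no higher from compound 2 to compound 4 (the limit leaves the size open) is thus not readable beyond the scatter.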

Compound 4, half-maximal inhibitory concentration: > 50000 nM
Compound 4 was reported as a limit; the forecaster's own chance of this, stated with the estimate: 60%; the middle value sits exactly at the limit.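

No step can be read between compound 2 and compound 4, because both sit at the limit: the limit of > 50000 nM in this assay, at which 3 of the 4 values shown sit.

As far as these compounds go, whether 3-fluorophenyl and 4-nitrophenyl differ in effect on the shared core remains open.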